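A few compounds are considered here, and "the series" means these few. Any claim that something is new, unique, unknown or untested is made for them only; others in the source may bear on it.

In a functional assay on HepG2 cells (Homo sapiens) for cytotoxicity, with a stated time of 72 h (a higher number here means that more compound is needed for the effect, a lower number that less compound is needed), compound 1 (`C=C[C@@](C)(/C=C/c1ccc(OS(=O)(=O)c2ccc(C)cc2)cc1)CCC=C(C)C`) gives > 52000 nM as a limit and not a number. Compound 2 (`C=C[C@@](C)(/C=C/c1ccc(O)cc1)CC/C=C(C)/C=C/C(=O)OCc1ccccc1`) gives > 52000 nM as a limit as well. Compound 3 (`C=C[C@@](C)(/C=C/c1ccc(O)c(CO)c1)CCC=C(C)C`) gives > 52000 nM as a limit too. Compound 3 therefore has no number of its own and shares its limit with compound 1 and compound 2 (the limit of > 52000 nM in this assay, at which 3 of the 3 values shown sit). The order among the three cannot be read from these results.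

Compound 4 (`C=C[C@@](C)(/C=C/c1ccc(O)c(/C=C/C#N)c1)CCC=C(C)C`) carries 2-cyanoethenyl in place of hydroxymethyl on an aromatic carbon, ortho to a hydroxy group (2-cyanoethenyl in place of hydroxymethyl on an aromatic carbon). Going by the values given here, no step between measured compounds is available to size this change. A small move toward a lower number is expected, or none beyond the scatter, and compound 4 may well return only the same limit. That expectation rests on the limit of compound 3 (> 52000 nM) alone. The expected step (an at least 1.3-fold lower number from compound 3 to compound 4 (0.11 log units; that floor lies within the scatter)) is an estimate only. For compound 4 the estimated value is (40000 nM), with an expected range of (15000 nM to 60000 nM).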

Compound 4, half-maximal effective concentration: > 52000 nM
Compound 4 was reported as a limit (the forecaster's own chance of this, stated with the estimate: 60%); middle value at least 1.3-fold (0.11 log units) from the limit.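

Compound 3 and compound 4 both return only a limit in this assay, so no step can be read for 2-cyanoethenyl in place of hydroxymethyl: the limit of > 52000 nM in this assay, at which 4 of the 4 values shown sit. The compounds shown leave open whether any change to the shared core gives a number rather than a limit in this assay.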